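Replacing the formyl group of compound 3

This account rests on a few compounds, and the source may have more. Where it says the series, first, only, none or still open, it means among the compounds named here.

Of the compounds shown here, three sharing the core of compound 1 have been tested in a functional assay on Hs-578T cells (Homo sapiens) for antiproliferative activity; a lower number here means a stronger inhibitor of growth, a higher number a weaker inhibitor of growth. For the measured compounds named here, compound 1 `COCCCCCCCCCCCCCCC/C=C1\CC(CO)(COC(=O)C(C)(C)C)OC1=O` gives 5.45 ug/mL, the only numeric reading of the three. Compound 2 `COC(=O)CCCCCCCCCCCCCC/C=C1\CC(CO)(COC(=O)C(C)(C)C)OC1=O` gives > 10 ug/mL, which is a limit of the assay. Compound 3 `CC(C)(C)C(=O)OCC1(CO)C/C(=C\CCCCCCCCCCCCCCC=O)C(=O)O1` gives > 10 ug/mL, again a limit. On these data alone, compound 3 therefore stands at the limit of > 10 ug/mL in this assay, at which 2 of the 3 values shown sit, and its true value is unknown.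

Compound 4 `CC(C)(C)C(=O)OCCCCCCCCCCCCCCC/C=C1\CC(CO)(COC(=O)C(C)(C)C)OC1=O` differs from compound 3 as follows: (((tert-butyl)carbonyl)oxy)methyl in place of formyl on a saturated chain carbon, ten or more bonds along the chain from a double-bonded chain carbon. Here (((tert-butyl)carbonyl)oxy)methyl takes the place of formyl on a saturated chain carbon.

Going by the values given here, three measured steps bear on this place. Formyl in place of methoxymethyl gave an at least 1.8-fold higher number from compound 1 to compound 3 (0.26 log units; that floor lies within the scatter), and methoxycarbonyl in place of methoxymethyl gave an at least 1.8-fold higher number from compound 1 to compound 2 (0.26 log units; that floor lies within the scatter). Hydrogen in place of methoxy on a carbonyl carbon gave a step that the two limits leave unreadable from compound 2 to compound 3. None of these steps has a firm size, and the entering group has not been tested at this place, so no clear direction can be drawn from them. Compound 1 at 5.45 ug/mL is the only numeric anchor. A reading near the limit remains the likeliest outcome. The expected change is an at least 1.1-fold lower number from compound 3 to compound 4 (0.04 log units; that floor lies within the scatter). Compound 4 is estimated at 9 ug/mL, with an expected range from 4 ug/mL to 20 ug/mL.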

Compound 4, concentration for 50% growth inhibition: 5.24 ug/mL
Estimate against measurement, compound 4: 1.7-fold (0.23 log units) above, within the range that was stated.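

In this assay, compound 4 gives this place on a saturated chain carbon a second numeric reading, and the change from formyl amounts to an at least 1.9-fold lower number from compound 3 to compound 4 (0.28 log units; that floor lies within the scatter), while the change from methoxycarbonyl amounts to an at least 1.9-fold lower number from compound 2 to compound 4 (0.28 log units; that floor lies within the scatter). For the compounds shown here, the more telling comparison is with the only earlier numeric reading: a 1.0-fold lower number from compound 1 to compound 4 (0.02 log units; within the scatter), so (tert-butyl)carbonyl and methyl on that oxygen read alike here. Compounds 1 and 4 both carry an oxygen on the saturated carbon at the chain end, whereas compounds 2 and 3, which end in methoxycarbonyl and formyl, remain at a limit of the assay: the limit of > 10 ug/mL in this assay, at which 2 of the 4 values shown sit.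

On these data alone, how far compounds 2 and 3 really lie from compound 4 stays unknown, and the step between compounds 2 and 3 still cannot be read. As far as these compounds go, whether that oxygen on a saturated carbon is what separates the two pairs also remains open, and a hydroxymethyl group, an aminomethyl group or a carboxylic acid at the chain end would put this to the test.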